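From 2-hydroxyethyl to ethoxy on the shared core

The compounds below may be only part of what the source reports. "The series", "measured", "known", "first", "only" and "open" are said of these compounds alone.

In a physicochemical assay for lipophilicity, at pH 7.4 (on this read-out lower numbers stand for lower lipophilicity and higher numbers for higher lipophilicity), compound 2 (`Cc1cc(Nc2ccc(C(F)(F)F)cc2)n2nc(CCO)nc2n1`) gives 2.2, within the scatter of compound 1 (`COCc1nc2nc(C)cc(Nc3ccc(C(F)(F)F)cc3)n2n1`) at 2.5, while compound 3 (`CCc1nc2nc(C)cc(Nc3cccc(Cl)c3)n2n1`) gives 2.8. The gap between compound 2 and compound 3 lies beyond the scatter. Compound 4 (`CCOc1nc2nc(C)cc(Nc3ccc(C(F)(F)F)cc3)n2n1`) is not yet measured. It has the same atoms as compound 2, joined differently: ethoxy in place of 2-hydroxyethyl on an aromatic carbon, with ethoxy in place of 2-hydroxyethyl on an aromatic carbon. Among the measured compounds shown here, the one measured step that bears on this, with hydroxymethyl in place of methoxy, is a number 0.30 log units lower from compound 1 to compound 2 (within the scatter). Read in reverse, that small step points to a modest rise, though no measured step covers ethoxy itself. The expected step is a number 0.50 log units higher from compound 2 to compound 4 (beyond the scatter). For compound 4 the estimate is 2.7, with an expected range of 2.3 to 3.1.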

Compound 4, distribution coefficient: 3.1
Beside the measured number, compound 4's estimate is 0.40 log units below it; low and high end bracket the measured number.
By their numbers in this assay, from the lowest: compounds 2, 1, 3 and 4 (each within the scatter of the next, the first and the last beyond it).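

At this aromatic carbon between two ring nitrogen atoms, ethoxy in place of 2-hydroxyethyl gives in this assay a number 0.90 log units higher from compound 2 to compound 4 (beyond the scatter) and takes away the hydrogen-bond donor while the heavy atoms stay the same in number and kind. Ethoxy in place of methoxymethyl gives a number 0.60 log units higher from compound 1 to compound 4 (beyond the scatter) and so also lies beyond the scatter, unlike the earlier step on this chain. Going by these compounds, whether an amine or a longer chain here would follow these steps stays open. Nothing available explains the size of either step.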